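Diethylamino in Place of Dimethylamino: An Expected Small Step

The source may hold more compounds than are shown below. What is called first, only, known or untested is meant among the compounds shown, and "the series" means these compounds.

Three compounds sharing one core have been examined in an ADME assay on A549 cells (Homo sapiens) for cytotoxicity, read by resazurin assay, with a stated time of 48 h; a higher number here means that more compound is tolerated, a lower number that less compound is tolerated. For compound 1 (`CC(=O)Nc1ccc(NC(=O)c2cc(Cl)ccc2O)c(Cl)c1`) the entry reads "not determined" (no result reported), so it offers no number. Compound 2 (`CC(C)CNc1ccc(NC(=O)c2cc(Cl)ccc2O)c(Cl)c1`) gives 60000 nM, and compound 3 (`CN(C)c1ccc(NC(=O)c2cc(Cl)ccc2O)c(Cl)c1`) gives 85100 nM. Going by the values given here, these are the only two numbers available, and compound 3 lies within the scatter of compound 2.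

Compound 4 (`CCN(CC)c1ccc(NC(=O)c2cc(Cl)ccc2O)c(Cl)c1`) carries diethylamino in place of dimethylamino, on an aromatic carbon para to a large group: diethylamino in place of dimethylamino on an aromatic carbon. Among the compounds with values here, only one measured step changes this same place: dimethylamino in place of isobutylamino, a 1.4-fold higher number from compound 2 to compound 3 (0.15 log units; within the scatter). Within the data shown here, that step stays within the scatter, although no measured compound yet carries diethylamino. No step beyond the scatter is therefore expected in this assay. The expected change is small, a 1.3-fold lower number from compound 3 to compound 4 (0.12 log units; within the scatter). Compound 4 is estimated at 65000 nM, with an expected range of 30000 nM to 130000 nM.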

Compound 4, half-maximal cytotoxic concentration: 55500 nM
Estimate against measurement, compound 4: 1.2-fold (0.07 log units) above; measured number inside the range.
By their numbers in this assay, from the lowest: compounds 4, 2 and 3 (each within the scatter of the next).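

The diethylamino compound adds a second tertiary-looking case only in name; what counts is that the position has now been probed with a third group, and in this assay each new step stays within the scatter: a 1.5-fold lower number from compound 3 to compound 4 (0.19 log units; within the scatter) and a 1.1-fold lower number from compound 2 to compound 4 (0.03 log units; within the scatter). Before this result, a single step rested on this aromatic carbon; now isobutylamino, dimethylamino and diethylamino all lie within the scatter of one another, and enlarging the group from 3 to 5 heavy atoms leaves the number where it was within that scatter. No measurement at hand offers any explanation for how closely these numbers lie.

Steps to compound 1 cannot be read, as it offers no number. From the compounds shown here alone, whether a carboxylic acid, a morpholine ring or a much longer chain on this carbon would move the number beyond the scatter stays open.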